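Swapping a dichlorinated benzyl group for a methylated one

A few compounds are considered here, and "the series" means these few. Any claim that something is new, unique, unknown or untested is made for them only; others in the source may bear on it.

compound 1, `Cc1ccc(Cn2cc(CSC(=S)N3CCN(C(=O)OC(C)(C)C)CC3)nn2)cc1`: 19700 nM
compound 2, `S=C(SCc1cn(Cc2ccccc2Cl)nn1)N1CCNCC1`: 38900 nM
compound 3, `S=C(SCc1cn(Cc2ccc(Cl)c(Cl)c2)nn1)N1CCNCC1`: "not determined" (no result reported)

All three compounds share the same core, a triazole carrying a benzyl group on one side and a sulfur-linked piperazine dithiocarbamate on the other, and were tested in a functional assay on MCF7 cells (Homo sapiens) for inhibition, read by MTT assay, with a stated time of 72 h; on this read-out higher numbers stand for weaker inhibition and lower numbers for stronger inhibition. Compound 3 stands without a number: in this assay compound 3 is recorded as "not determined" (no result reported), so it offers no anchor of its own. The step to compound 4 is 4-methylphenyl in place of 3,4-dichlorophenyl on a saturated chain carbon bound to an aromatic nitrogen, which gives compound 4 `Cc1ccc(Cn2cc(CSC(=S)N3CCNCC3)nn2)cc1`. Within the data shown here, because compound 3 has no value, the size and direction of this step cannot be read from the data, and no step between measured compounds is available. What can be said rests on the two measured neighbours. In this assay compound 1 gives 19700 nM and compound 2 gives 38900 nM; these two values lie within the usual scatter of each other, so neither can be called stronger. Compound 4 carries the free piperazine of compound 2 and the 4-methylphenyl group of compound 1, so weak inhibition of the same order is expected, with no change beyond the scatter anticipated against either measured compound. Compound 4 is estimated at 30000 nM, with a range from 12000 nM to 80000 nM.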

Compound 4, half-maximal inhibitory concentration: 53200 nM
The estimate for compound 4 lay 1.8-fold (0.25 log units) below the measured number, within the range that was stated.
By their numbers in this assay, from the lowest: compounds 1, 2 and 4 (each within the scatter of the next, the first and the last beyond it).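

In this assay the position on a saturated chain carbon bound to an aromatic nitrogen now has its first one-place comparison: 4-methylphenyl in place of 2-chlorophenyl gives a 1.4-fold higher number from compound 2 to compound 4 (0.14 log units; within the scatter) and so leaves these two groups indistinguishable here. The change of hydrogen in place of tert-butoxycarbonyl on an amine nitrogen in a ring gives a 2.7-fold higher number from compound 1 to compound 4 (0.43 log units; beyond the scatter) and is the only step shown that exceeds the scatter, a modest loss of inhibition on removing the tert-butoxycarbonyl group. Compounds 1 and 2 differ in more than one place, so compound 4 is what allows these two changes to be viewed separately, although every compound with a number remains a weak inhibitor in this assay.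

No measurement shown explains either step. From the compounds shown here alone, the step from 3,4-dichlorophenyl cannot be read, and it remains open whether a methoxy group or a nitrile on the benzyl ring, or an acetyl group or a longer chain on the piperazine nitrogen, would move the number beyond the scatter.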